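Carboxymethyl to 1-carboxyethyl across two cores

The source may hold more compounds than are shown below. What is called first, only, known or untested is meant among the compounds shown, and "the series" means these compounds.

Measured so far:
- compound 1 `CC(C(=O)O)c1nn(Cc2cn3cc(OCC4CC4)c(Cl)cc3n2)c2ccccc2c1=O`: 80 mL/min/kg
- compound 2 `O=C(O)Cn1nc(Cn2cc3cc(OCC4CC4)c(Cl)cc3n2)c2ccccc2c1=O`: < 85 mL/min/kg (a limit of the assay)
- compound 3 `O=C(O)Cc1nn(Cc2cn3cc(OCC4CC4)c(Cl)cc3n2)c2ccccc2c1=O`: < 51.7 mL/min/kg (a limit of the assay)

In an ADME assay on microsomes from liver (Mus musculus) for metabolic stability (on this read-out higher numbers stand for fast clearance and lower numbers for slow clearance), compound 1 gives 80 mL/min/kg. For compound 3 the read-out is a limit of the assay, < 51.7 mL/min/kg. For compound 2 likewise only a limit is reported, < 85 mL/min/kg. The change methyl in place of hydrogen on a saturated chain carbon bound to an aromatic carbon and a carbonyl carbon carries an at least 1.5-fold higher number from compound 3 to compound 1 (0.18 log units; that floor lies within the scatter); with compound 3 at a limit (the limit of < 51.7 mL/min/kg in this assay, at which 1 of the 3 values shown sits), the true size of that step is open at the low end.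

Compound 4 `C[C@H](C(=O)O)n1nc(Cn2cc3cc(OCC4CC4)c(Cl)cc3n2)c2ccccc2c1=O` is not yet measured. It differs from compound 2 by methyl in place of hydrogen on a saturated chain carbon bound to an aromatic nitrogen and a carbonyl carbon. This is the same kind of change as from compound 3 to compound 1, not the same: there the chain carbon is bound to an aromatic carbon and a carbonyl carbon, here to an aromatic nitrogen and a carbonyl carbon. The difference between the cores of compound 2 and compound 3 is not broken down here.

For compound 4 the expected step is a number no lower from compound 2 to compound 4 (the limit leaves the size open), resting on the same direction as an at least 1.5-fold higher number from compound 3 to compound 1 (0.18 log units; that floor lies within the scatter), with the starting point itself uncertain since compound 2 sits at the limit of < 85 mL/min/kg in this assay, at which 1 of the 3 values shown sits. Compound 4 is estimated at 85 mL/min/kg, between 45 mL/min/kg and 160 mL/min/kg.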

Compound 4, clearance in the Mus musculus assay: < 66.7 mL/min/kg
Compound 4: a limit, no number; the forecaster's own chance of this, stated with the estimate: 35%; middle value at least 1.2-fold (0.10 log units) from the limit.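

In the Mus musculus assay compound 2 gives < 85 mL/min/kg as a limit of the assay. In the Mus musculus assay compound 4 gives < 66.7 mL/min/kg as a limit of the assay too. The step between these two compounds cannot be read. The compounds shown leave open whether carboxymethyl to 1-carboxyethyl on this core moves clearance in the same direction as the step from compound 3 to compound 1. In a physicochemical assay for solubility, measured as thermodynamic solubility, at pH 7.4 (on this read-out lower numbers stand for lower solubility and higher numbers for higher solubility), compound 2 gives 334 ug/mL as its measured value. In the physicochemical assay compound 4 gives 958 ug/mL as its measured value. In the physicochemical assay the change shows a 2.9-fold higher number from compound 2 to compound 4 (0.46 log units; beyond the scatter) on this read-out.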